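Amide aryl variation: dichlorophenyl in place of fluorophenyl

The compounds below may be only part of what the source reports. "The series", "measured", "known", "first", "only" and "open" are said of these compounds alone.

Three compounds carry the measurements so far. Compound 1 `Cc1cc(NCCN2CCN(C)CC2)nc2ccc(NC(=O)c3ccc(Cl)c(Cl)c3)cc12` gives 1700 nM in a functional assay on MCF7 cells (Homo sapiens) for antiproliferative activity, read by MTT assay, with a stated time of 72 h; a higher number here means a weaker inhibitor, a lower number a stronger inhibitor. Compound 2 `CCc1ccc(C(=O)Nc2ccc3nc(N4CCN(CC)CC4)cc(C)c3c2)cc1` gives 3060 nM in this assay, and compound 3 `CCN1CCN(c2cc(C)c3cc(NC(=O)c4cccc(F)c4)ccc3n2)CC1` gives 8920 nM in this assay, the highest number of the three; the nearest is compound 2, the furthest compound 1. The one step among these that changes only the aryl group on the carbonyl carbon is a 2.9-fold higher number from compound 2 to compound 3 (0.46 log units; beyond the scatter).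

Compound 4 `CCN1CCN(c2cc(C)c3cc(NC(=O)c4ccc(Cl)c(Cl)c4)ccc3n2)CC1` differs from compound 3 as follows: 3,4-dichlorophenyl in place of 3-fluorophenyl on a carbonyl carbon. Within the data shown here, no step between measured compounds covers this exact change on the shared core of compound 3. Compound 1, which carries the same 3,4-dichlorophenyl on a different core, shows 1700 nM, the lowest number of the set, and compound 3 with 3-fluorophenyl stands highest. The expectation in this assay is therefore a lower number for compound 4, a step of modest size in the direction of stronger inhibition, beyond the scatter.

Compound 4 is estimated at 2500 nM, with a range from 1000 nM to 6000 nM; this estimate means a step of a 3.6-fold lower number from compound 3 to compound 4 (0.55 log units; beyond the scatter).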

Compound 4, half-maximal inhibitory concentration: 1380 nM
For compound 4 the middle estimate is 1.8-fold (0.26 log units) above the measured one; low and high end bracket the measured number.
By their numbers in this assay, from the lowest: compounds 4, 1 and 2 (each within the scatter of the next, the first and the last beyond it); then compound 3.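

On the core shared by compounds 2, 3 and 4, the aryl group on the carbonyl carbon changes the number in this assay more widely than the earlier step showed: 3,4-dichlorophenyl in place of 3-fluorophenyl gives a clear drop (a 6.5-fold lower number from compound 3 to compound 4 (0.81 log units; beyond the scatter)), and 3,4-dichlorophenyl in place of 4-ethylphenyl gives a smaller one (a 2.2-fold lower number from compound 2 to compound 4 (0.35 log units; beyond the scatter)). With 3,4-dichlorophenyl held fixed, 4-ethylpiperazin-1-yl in place of (2-(4-methylpiperazin-1-yl)ethyl)amino on the aromatic carbon leaves the number within the scatter (a 1.2-fold lower number from compound 1 to compound 4 (0.09 log units; within the scatter)). No supporting data at hand account for these differences.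

Still open, going by these compounds, is whether a nitrile or a carboxylic acid on the aryl group would hold the number as low as the two chlorines do. Also open, on these data alone, is whether the two groups on the aromatic carbon remain within the scatter of each other when the amide carries 3-fluorophenyl or 4-ethylphenyl.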